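The source may hold more compounds than are shown below. What is called first, only, known or untested is meant among the compounds shown, and "the series" means these compounds.

Compound 2 `COc1ncc(C(C)(C)C)cc1CN[C@H]1[C@H](C(C)(C)C)[C@@H](C(=O)O)N(C(=O)C2CCCCC2)[C@H]1c1ccccc1` has the lowest number of the two measured in an assay on HBE cells for positive allosteric modulation of Cystic fibrosis transmembrane conductance regulator variant F508del (Homo sapiens) (a lower number here means that less compound is needed, a higher number that more compound is needed for the effect), where compound 2 gives 107 nM; compound 1 `COc1ccc(Cl)cc1CN[C@H]1[C@H](C(C)(C)C)[C@@H](C(=O)O)N(C(=O)C2CCCCC2)[C@H]1c1ccccc1` gives 241 nM, a step of a 2.3-fold lower number from compound 1 to compound 2 (0.35 log units; beyond the scatter). Compound 3 `COc1ncc(C(F)(F)F)cc1CN[C@H]1[C@H](C(C)(C)C)[C@@H](C(=O)O)N(C(=O)C2CCCCC2)[C@H]1c1ccccc1` differs from compound 2 by trifluoromethyl in place of tert-butyl on an aromatic carbon. Among the compounds with values here, no measured step exchanges one group for another at that place; the only recorded step swaps the whole aryl group, so it gives little guidance on this change. A step of a 1.4-fold higher number from compound 2 to compound 3 (0.15 log units; within the scatter) is therefore expected, within the usual scatter. Compound 3 is estimated at 150 nM, with a range from 60 nM to 400 nM.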

Compound 3, half-maximal effective concentration: 210 nM
Compound 3: the middle estimate sits 1.4-fold (0.15 log units) below what was measured, and the stated range covers the measured number.
By their numbers in this assay, from the lowest: compounds 2, 3 and 1 (each within the scatter of the next, the first and the last beyond it).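

In this assay the exchange of tert-butyl for trifluoromethyl on this aromatic carbon gives a 2.0-fold higher number from compound 2 to compound 3 (0.29 log units; within the scatter) and so does not separate the two groups at this position. The swap of the whole aryl group gives a 1.1-fold lower number from compound 1 to compound 3 (0.06 log units; within the scatter) and shows that 2-methoxy-5-(trifluoromethyl)pyridin-3-yl and 5-chloro-2-methoxyphenyl are not told apart either. No evidence bears on this result. Still open, going by these compounds, is whether a nitrile, a methyl or an amine at this place would shift the number beyond the scatter.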